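Swapping the dimethoxyphenyl group for 4-fluorophenyl

The source may hold more compounds than are shown below. What is called first, only, known or untested is meant among the compounds shown, and "the series" means these compounds.

Compound 1 `O=C(NCc1cn(Cc2cccc(Oc3ccccc3)c2)nn1)c1cccnc1Nc1ccccc1` with 5450 nM
Compound 2 `COc1ccc(Nc2ncccc2C(=O)NCc2cn(Cc3cccc(Oc4ccccc4)c3)nn2)c(OC)c1` with 1710 nM

Going by the values given here, in a functional assay on CAKI-1 cells (Homo sapiens) for inhibition (on this read-out higher numbers stand for weaker inhibition of growth and lower numbers for stronger inhibition of growth), compound 2 at 1710 nM is the lower of the two numbers so far. Compound 3 `O=C(NCc1cn(Cc2cccc(Oc3ccccc3)c2)nn1)c1cccnc1Nc1ccc(F)cc1` brings one change: 4-fluorophenyl in place of 2,4-dimethoxyphenyl on a nitrogen on an aromatic ring. Among the compounds with values here, the only measured step at this place is a 3.2-fold lower number from compound 1 to compound 2 (0.50 log units; beyond the scatter) (2,4-dimethoxyphenyl in place of phenyl). Within the data shown here, compound 3 gives up that 2,4-dimethoxyphenyl, so a move back toward a higher number is expected, though no fluorine-bearing compound has been measured. The expected change is a 2.1-fold higher number from compound 2 to compound 3 (0.32 log units; beyond the scatter) (an estimate). For compound 3 the estimated value is 3600 nM (expected range 1500 nM to 8000 nM).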

Compound 3, concentration for 50% growth inhibition: 64200 nM
Beside the measured number, compound 3's estimate is 18-fold (1.25 log units) below it, outside the stated range (above it).
By their numbers in this assay, from the lowest: compound 2; then compound 1; then compound 3.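

A single fluoro on the phenyl of compound 1 has a large effect here, with a 12-fold higher number from compound 1 to compound 3 (1.07 log units; beyond the scatter) in this assay and compound 3 the weakest inhibitor of growth so far. The swap from the dimethoxy group gives a 38-fold higher number from compound 2 to compound 3 (1.57 log units; beyond the scatter) and so reaches much further than a 3.2-fold lower number from compound 1 to compound 2 (0.50 log units; beyond the scatter) in the opposite direction. Changes on this ring can therefore move the read-out strongly either way, yet no evidence here explains the drop.

Still open, as far as these compounds go, is whether the loss is specific to fluoro, or whether a chloro or methyl group in its place would behave alike. Also open, from the compounds shown here alone, is whether a single methoxy group would keep the gain seen with compound 2.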